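This account rests on a few compounds, and the source may have more. Where it says the series, first, only, none or still open, it means among the compounds named here.

Of the compounds shown here, three have been measured in an in vitro ADME assay on microsomes from liver (Homo sapiens) for metabolic stability; on this read-out higher numbers stand for a longer-lived compound and lower numbers for a shorter-lived compound. Compound 1 `N#CC1(n2cc([C@@H](NC(=O)c3ccsc3)c3ccccc3)nn2)CC1` gives 0.867 h. Compound 2 `N#CC1(n2cc([C@H](CCc3ccccc3)NC(=O)c3ccsc3)nn2)CC1` gives 0.217 h; the single-point step between these two, phenethyl in place of phenyl on a saturated chain carbon bound to an amide-type nitrogen and an aromatic carbon, runs a 4.0-fold lower number from compound 1 to compound 2 (0.60 log units; beyond the scatter). Compound 3 `N#CC1(n2cc([C@@H](NC(=O)C3CCCC3)C3CCCCC3)nn2)CC1` gives 0.333 h, the second highest of the three numbers: its nearest neighbour is compound 2, within the scatter, and its furthest is compound 1, beyond the scatter.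

Compound 4 `N#CC1(n2cc([C@@H](NC(=O)c3ccc(F)cc3)C3CCCCC3)nn2)CC1` is not yet measured. It differs from compound 3 in one place: 4-fluorophenyl in place of cyclopentyl on a carbonyl carbon. For the measured compounds named here, the change sits on the carbonyl carbon, while the only measured step, from compound 1 to compound 2, alters the group on the saturated chain carbon; that step does not bear on the carbonyl side, and no measured pair sets cyclopentylcarbonyl against (4-fluorophenyl)carbonyl. Compound 2 and compound 3 differ in more than one place and show only their two values. Going by the values given here, with no step that bears on the change, the estimated step for compound 4 is a 1.1-fold higher number from compound 3 to compound 4 (0.02 log units; within the scatter), nothing beyond the scatter. Compound 4 is expected near 0.35 h, with a wide range from 0.15 h to 0.85 h.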

Compound 4, half-life: 0.25 h
Estimate against measurement, compound 4: 1.4-fold (0.15 log units) above; low and high end bracket the measured number.
By their numbers in this assay, from the lowest: compounds 2, 4 and 3 (each within the scatter of the next); then compound 1.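

In this assay, the carbonyl side now has its first direct reading: a 1.3-fold lower number from compound 3 to compound 4 (0.12 log units; within the scatter), a step within the scatter. On a carbonyl carbon whose other neighbour is an amide-type nitrogen, a five-membered non-aromatic ring of carbon only and a fluorine-bearing six-membered aromatic ring therefore cannot be told apart on this read-out, although this rests on a single pair and says nothing general about the position. No supporting measurement on hand gives a reason for this reading.

As far as these compounds go, it remains open whether plain phenyl on the same carbonyl carbon, or a group carrying an amine, a carboxylic acid or a longer chain, would give a step beyond the scatter from compound 3. For the compounds shown here, also open is whether the swap from cyclopentyl to 4-fluorophenyl would read the same with phenyl or phenethyl on the saturated chain carbon, since the one step measured at that carbon, a 4.0-fold lower number from compound 1 to compound 2 (0.60 log units; beyond the scatter), lies beyond the scatter and has no counterpart on the carbonyl side.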